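The source may report more compounds than this note shows. Statements on the series, on what has been measured and on what is new or still open speak of the compounds shown alone.

Compound 1, `CCCCOc1ccc(-c2nc3ncccn3c2NC2CCCC2)cc1`, in a toxicity assay on A549 cells (Homo sapiens) for cytotoxicity, read by luminescence and CellTiter-Glo, with a stated time of 48 h; a lower number here means that less compound is tolerated, a higher number that more compound is tolerated: 40000 nM
Compound 2, `CCCCOc1ccc(-c2nc3ncccn3c2NC(C)(C)CC(C)(C)C)cc1`, in this assay: 29000 nM

Among these two numbers compound 1 stands highest with 40000 nM, but only just: the step of a 1.4-fold lower number from compound 1 to compound 2 (0.14 log units; within the scatter) is within the scatter, so the two compounds cannot be ordered. Compound 3, `CCCCOc1ccc(-c2nc3ncccn3c2Nc2ccccc2)cc1`, keeps the shared core and differs from compound 1 by phenyl in place of cyclopentyl on a nitrogen on an aromatic ring. Among the measured compounds shown here, the only measured step that bears on this change is the one from compound 1 to compound 2, which swaps the group on the same nitrogen, and that step, a 1.4-fold lower number from compound 1 to compound 2 (0.14 log units; within the scatter), is within the scatter. Nothing here shows that exchanging the group on this nitrogen moves the number, so compound 3 is expected to sit close to compound 1. Compound 3 is estimated at 35000 nM, with a range of 15000 nM to 80000 nM. The expected step of a 1.1-fold lower number from compound 1 to compound 3 (0.06 log units; within the scatter) is within the scatter.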

Compound 3, half-maximal cytotoxic concentration: 100000 nM
For compound 3 the middle estimate is 2.9-fold (0.46 log units) below the measured one; the measured number lies above the stated range.
By their numbers in this assay, from the lowest: compounds 2 and 1 (each within the scatter of the next); then compound 3.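

In this assay the group on this nitrogen does shift the number: phenyl in place of cyclopentyl gives a 2.5-fold higher number from compound 1 to compound 3 (0.40 log units; beyond the scatter) and phenyl in place of 1,1,3,3-tetramethylbutyl gives a 3.4-fold higher number from compound 2 to compound 3 (0.54 log units; beyond the scatter) as well. The two non-aromatic carbon groups could not be ordered, so the first sign that this position matters comes with the aromatic ring. That sign points towards more compound being tolerated, although both steps are modest.

With only one aromatic group shown, it stays open whether a benzyl group, a pyridine ring or a phenyl ring carrying a methoxy group would behave like phenyl. Nothing measured here accounts for the shift.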